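Thiophen-2-yl for 3-methoxyphenyl on a shared core

A few compounds are considered here, and "the series" means these few. Any claim that something is new, unique, unknown or untested is made for them only; others in the source may bear on it.

Compound 1 `COc1cccc(/C=C/C(=O)c2ccc(OC)c3c2OC(C)(C)C=C3)c1` was examined in a functional assay on SK-OV-3 cells (Homo sapiens) for antiproliferative activity, read by MTT assay, with a stated time of 24 h (a higher number here means a weaker inhibitor, a lower number a stronger inhibitor), where compound 1 gives 9360 nM. Of the two compounds for which a number was obtained, compound 1 has the highest value; its nearest neighbour is compound 2 `COc1ccc(C(=O)/C=C/c2ccc3ccccc3n2)c2c1C=CC(C)(C)O2`, which in this assay gives 2350 nM, a gap that lies beyond the usual scatter of repeated measurements. Compound 3 `COc1ccc(C(=O)/C=C/c2cccc3ccccc23)c2c1C=CC(C)(C)O2` in this assay reaches only > 10000 nM, which is a limit of the assay rather than a number, as described by the limit of > 10000 nM in this assay, at which 1 of the 3 values shown sits.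

Compound 4 `COc1ccc(C(=O)/C=C/c2cccs2)c2c1C=CC(C)(C)O2` has not been measured yet. It differs from compound 1 in one place: thiophen-2-yl in place of 3-methoxyphenyl on a double-bonded chain carbon bound to a double-bonded chain carbon. Going by the values given here, no pair of the measured compounds differs in a single place, so the size of this step cannot be read from any measured neighbour. The step of a 1.3-fold lower number from compound 1 to compound 4 (0.13 log units; within the scatter) is expected to be small, toward a lower number, and may well stay within the scatter. Compound 4 is therefore estimated to give 7000 nM in this assay, with a plausible range from 2500 nM to 20000 nM.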

Compound 4, half-maximal inhibitory concentration: > 10000 nM
Compound 4: only a limit was reported; the forecaster's own chance of this, stated with the estimate: 25%; middle value at least 1.4-fold (0.15 log units) from the limit.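

In this assay compound 4 gives > 10000 nM, which is a limit of the assay and not a number. Thiophen-2-yl in place of 3-methoxyphenyl on a double-bonded chain carbon bound to a double-bonded chain carbon gives an at least 1.0-fold higher number from compound 1 to compound 4 (0.02 log units; that floor lies within the scatter), so this change at this position gives no lower number, and only a floor for the step can be read, not its true size. This is the first single-place change that can be read at this position, and it leaves compound 4 among the compounds that yield only a limit: the limit of > 10000 nM in this assay, at which 2 of the 4 values shown sit.

As far as these compounds go, how far compound 4 actually lies from compound 1 remains open. Also open, from the compounds shown here alone, is whether an amine or a carboxylic acid in place of 3-methoxyphenyl at this position would give a lower number than compound 1.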